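A few compounds are considered here, and "the series" means these few. Any claim that something is new, unique, unknown or untested is made for them only; others in the source may bear on it.

Compound 1 `C=CCSc1nncc2cnc(CCC)n12`: > 48000 nM
Compound 2 `CC(C)c1ncn2c(Nc3cc[nH]n3)nccc12`: > 48000 nM

In a functional assay for inhibition, with Homo sapiens as the target (on this read-out higher numbers stand for weaker inhibition and lower numbers for stronger inhibition), compound 1 returns only > 48000 nM, which is a limit of the assay and not a number. Compound 2 likewise gives only > 48000 nM, again a limit. Both results sit at the limit of > 48000 nM in this assay, at which 2 of the 2 values shown sit, so compound 1 stands nowhere distinct on these numbers. Compound 3 `C=CCSc1nncc2cnc(COC)n12` differs from compound 1 by methoxy in place of ethyl on a saturated chain carbon bound to an aromatic carbon. Among the compounds with values here, with no measured step to lean on, the expected change from compound 1 to compound 3 is a step that the limit leaves unreadable from compound 1 to compound 3, none beyond the scatter. Compound 3 is therefore estimated at 60000 nM, within 20000 nM to 200000 nM, most likely again reported only as a limit.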

Compound 3, half-maximal inhibitory concentration: 79000 nM
For compound 3 the middle estimate is 1.3-fold (0.12 log units) below the measured one; measured number inside the range.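

In this assay, within the data shown here, no step from compound 1 to compound 3 can be read, because the result for compound 1 is only a limit: the limit of > 48000 nM in this assay, at which 2 of the 3 values shown sit. The compounds shown leave open whether methoxy in place of ethyl changes inhibition at all.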